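Benzyl for Methyl on a Weak Thiazolidinedione Aniline

The source may hold more compounds than are shown below. What is called first, only, known or untested is meant among the compounds shown, and "the series" means these compounds.

Measured compounds:
Compound 1 `C=C(Br)C(=O)Nc1ccc(/C=C2\SC(=O)N(Cc3ccccc3)C2=O)cc1`: 1100 nM
Compound 2 `C=C(Br)C(=O)Nc1ccc(/C=C2\SC(=O)N(C)C2=O)cc1`: 190 nM
Compound 3 `CN1C(=O)S/C(=C\c2ccc(N)cc2)C1=O`: 99000 nM

In a functional assay on L1210 cells (Mus musculus) for cytotoxicity, read by cell counting, with a stated time of 2 days (a higher number here means a weaker inhibitor, a lower number a stronger inhibitor), compound 2 gives 190 nM, and compound 1 gives 1100 nM. The change between them is phenyl in place of hydrogen on a saturated chain carbon bound to an amide-type nitrogen in a ring, which made a step of a 5.8-fold higher number from compound 2 to compound 1 (0.76 log units; beyond the scatter). Compound 3 gives 99000 nM, the weakest of the three. Compound 3 differs from compound 2 in its core: hydrogen in place of (1-bromoethenyl)carbonyl on a nitrogen on an aromatic ring, a step of a 520-fold higher number from compound 2 to compound 3 (2.72 log units; beyond the scatter).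

Compound 4 `Nc1ccc(/C=C2\SC(=O)N(Cc3ccccc3)C2=O)cc1` is not yet measured. It differs from compound 3 by phenyl in place of hydrogen on a saturated chain carbon bound to an amide-type nitrogen in a ring, the same change as between compound 2 and compound 1, and the place lines agree word for word. The earlier step weakened the compound modestly, so compound 4 is expected to be weaker than compound 3, with a step estimated at a 4.5-fold higher number from compound 3 to compound 4 (0.66 log units; beyond the scatter), resting on the earlier step of a 5.8-fold higher number from compound 2 to compound 1 (0.76 log units; beyond the scatter). The number for compound 4 is estimated at 450000 nM, between 120000 nM and 2000000 nM, with a fair chance that only a limit is reported.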

Compound 4, half-maximal inhibitory concentration: 38000 nM
The estimate for compound 4 lay 12-fold (1.07 log units) above the measured number; measured number outside the range, below it.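

In this assay, going from methyl to benzyl gave a 2.6-fold lower number from compound 3 to compound 4 (0.42 log units; beyond the scatter), so the change that weakened the compound carrying (1-bromoethenyl)carbonyl strengthened the compound without that group, and its effect did not carry from one core to the other: the same change on two cores in this assay, a 5.8-fold higher number (0.76 log units; beyond the scatter) from compound 2 to compound 1 and a 2.6-fold lower number (0.42 log units; beyond the scatter) from compound 3 to compound 4, 15-fold (1.18 log units) apart, beyond the scatter of two such steps. Replacing (1-bromoethenyl)carbonyl with hydrogen gave a 35-fold higher number from compound 1 to compound 4 (1.54 log units; beyond the scatter), a loss of strength with either methyl or benzyl present, though not a loss of one size: the same change on two cores in this assay, a 520-fold higher number (2.72 log units; beyond the scatter) from compound 2 to compound 3 and a 35-fold higher number (1.54 log units; beyond the scatter) from compound 1 to compound 4, 15-fold (1.18 log units) apart, beyond the scatter of two such steps. These four compounds show that the two changes do not act independently here, but they do not show why, or how either change would behave on any other core.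

Still open, on these data alone, is how an ethyl group or a longer chain on the amide-type nitrogen in a ring would compare with methyl and benzyl. Also open, as far as these compounds go, is whether a plain acetyl group on the nitrogen on the aromatic ring, which has no bromine, would keep numbers as low as those of compound 2 and compound 1.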